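A stability limit and an untested side chain

This account rests on a few compounds, and the source may have more. Where it says the series, first, only, none or still open, it means among the compounds named here.

- Compound 1 `CC(C)c1nc2c(C(=O)NCC3CCN(CCN4CCN(S(C)(=O)=O)CC4)CC3)cccc2[nH]1` gives > 1.5 h (a limit)
- Compound 2 `CC(=O)N1CCN(CCN2CCC(CNC(=O)c3cccc4[nH]c(C(C)C)nc34)CC2)CC1` gives > 1.5 h (a limit)

In an ADME assay on microsomes from liver (Rattus norvegicus) for metabolic stability (a lower number here means that the compound disappears faster, a higher number that the compound lasts longer), compound 2 stands at > 1.5 h as a limit and not a number. The whole record so far is the limit of > 1.5 h in this assay, at which 2 of the 2 values shown sit, and nothing more. Compound 3 `CC(=O)N(C)CC(O)CN1CCC(CNC(=O)c2cccc3[nH]c(C(C)C)nc23)CC1` differs from compound 2 in this way: 2-(acetyl(methyl)amino)-1-hydroxyethyl in place of (4-acetylpiperazin-1-yl)methyl on a saturated chain carbon bound to an amine nitrogen in a ring on a saturated chain carbon bound to an amine nitrogen in a ring. Among the measured compounds shown here, the only measured step is a step that the two limits leave unreadable from compound 1 to compound 2 and offers no size to carry over. No direction can be argued in this assay and no shift beyond the scatter is expected. The expected change is a number no higher from compound 2 to compound 3 (the limit leaves the size open) for now. The estimate for compound 3 is 1.5 h with 0.8 h to 3 h as the expected range.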

Compound 3, half-life: > 1.5 h
Compound 3: no number, only a limit (the forecaster's own chance of this, stated with the estimate: 60%); the middle value sits exactly at the limit.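

Among the compounds shown here, compound 1, compound 2 and compound 3 each give only a limit in this assay, so no step among them can be read. Still open is how long each compound actually lasts, and whether the side-chain changes matter: the limit of > 1.5 h in this assay, at which 3 of the 3 values shown sit.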